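The source may report more compounds than this note shows. Statements on the series, on what has been measured and on what is new or still open speak of the compounds shown alone.

Compound 1 `O=C(Cc1cccnc1)c1cc2cc(-c3ccccc3)ccc2[nH]1`: in an in vitro assay on P815B cells for inhibition of Indoleamine 2,3-dioxygenase 1 (Mus musculus), tested at 20 uM (on this read-out lower numbers stand for less inhibition and higher numbers for more inhibition at the one concentration tested (going by the name of the read-out)), compound 1 gives "not active" (no number reported).
Compound 2 `O=C(Cc1cccnc1)c1cc2ccccc2[nH]1`: in this assay compound 2 gives 13%.
Compound 3 `COc1ccc2[nH]c(C(=O)Cc3cccnc3)cc2c1`: in this assay compound 3 gives "not determined" (no result reported).

Among the compounds with values here, compound 2 holds the only number in this assay; the other two measured compounds carry no number at all, so no step between measured compounds can be compared. Compound 4 `O=C(Cc1ccccn1)c1cc2ccccc2[nH]1` keeps every atom of compound 2 but joins them differently: pyridin-2-yl in place of pyridin-3-yl on a saturated chain carbon bound to a carbonyl carbon. Within the data shown here, with only one number to go on, no clear direction can be read, and the change is expected to give a step of no change at the digits printed from compound 2 to compound 4 (within the scatter) in this assay, which would lie within the usual scatter. Compound 4 is therefore estimated to reach 13%, with a range from 2% to 26%.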

Compound 4, a percentage reported as inhibition, at one concentration (the size of the read-out at that concentration, not a potency): 10%
For compound 4 the middle estimate is 3 percentage points above the measured one; low and high end bracket the measured number.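

In this assay, pyridin-2-yl in place of pyridin-3-yl on a saturated chain carbon bound to a carbonyl carbon gives a number 3 percentage points lower from compound 2 to compound 4 (within the scatter). Within the data shown here, this is the first step that can be read, and it shows that these two groups cannot be told apart at this position. Nothing available explains this result. Still open, from the compounds shown here alone, is whether pyridin-4-yl or a plain phenyl ring at the same place would give a different reading. Also open, going by these compounds, is what a methoxy or phenyl group on the shared core does, as the entries with those groups carry no number.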